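Halogen Swap on a Weak Growth-Inhibitor Series

The compounds below may be only part of what the source reports. "The series", "measured", "known", "first", "only" and "open" are said of these compounds alone.

Of the compounds shown here, three have been tested in a functional assay on DU-145 cells (Homo sapiens) for inhibition, read by trypan blue exclusion, with a stated time of 96 h; a lower number here means a stronger inhibitor of growth, a higher number a weaker inhibitor of growth. Compound 1 `O=C(/C(=C\c1ccc(O)c([N+](=O)[O-])c1)S(=O)(=O)c1ccc(I)cc1)c1ccc(I)cc1` gives 25000 nM. Compound 3 `O=C(/C(=C\c1ccc(O)c([N+](=O)[O-])c1)S(=O)(=O)c1ccc(I)cc1)c1ccc(Br)cc1` carries bromo in place of iodo on an aromatic carbon and gives 25000 nM; the step of no change at the digits printed from compound 1 to compound 3 (within the scatter). Compound 2 `O=C(/C(=C/c1ccc(I)cc1)S(=O)(=O)Cc1ccc(I)cc1)c1ccc(Br)cc1` gives 20000 nM; how its core differs from that of compound 1 is not broken down here, and its number lies within the scatter of both other values, so no ordering among the three can be drawn.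

The change now of interest is bromo in place of iodo on an aromatic carbon, which leads from compound 2 to the unmeasured compound 4 `O=C(/C(=C/c1ccc(Br)cc1)S(=O)(=O)Cc1ccc(I)cc1)c1ccc(Br)cc1`. The place of the change reads the same as for the step from compound 1 to compound 3: on an aromatic carbon of a six-membered aromatic ring of carbon only, para to a large group. It is therefore the same change, made on a different core. Since that earlier step no change at the digits printed from compound 1 to compound 3 (within the scatter) showed no change within the scatter, compound 4 is expected to stay close to compound 2, with an estimated step of a 1.1-fold higher number from compound 2 to compound 4 (0.04 log units; within the scatter). Among the compounds with values here, the estimate for compound 4 in this assay is 22000 nM, with a range from 10000 nM to 50000 nM, resting on the one earlier example only.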

Compound 4, concentration for 50% growth inhibition: > 50000 nM
Compound 4 was reported as a limit (the forecaster's own chance of this, stated with the estimate: 15%); at least 2.2-fold (0.35 log units) between middle value and limit.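

On the core of compound 2, bromo in place of iodo gives an at least 2.5-fold higher number from compound 2 to compound 4 (0.39 log units; beyond the scatter) in this assay, so on this core the swap does not leave the reading unchanged as it did on the core of compound 1. Compound 4 stands at > 50000 nM, which is a limit of the assay and not a number: the limit of > 50000 nM in this assay, at which 1 of the 4 values shown sits. The two pairs therefore do not show that the change carries over unaltered from one core to the other, and they do not establish that it acts differently on the two cores either: the same change on two cores in this assay, no change at the digits printed (within the scatter) from compound 1 to compound 3 and an at least 2.5-fold higher number (0.39 log units; beyond the scatter) from compound 2 to compound 4; the limit leaves it open whether they differ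

The compounds shown leave open how a chloro or a fluoro on the same aromatic carbon would read on either core, and how an amine or a carboxylic acid there would read. Also open, from the compounds shown here alone, are the true value of compound 4 and the full size of its step, and anything said about this change rests on just two pairs in a single assay.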